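Pyridinyl ether series: amide in place of isobutyl

The source may hold more compounds than are shown below. What is called first, only, known or untested is meant among the compounds shown, and "the series" means these compounds.

Measured compounds:
compound 1 `CSc1ncccc1OC[C@@H]1CCCN1C`, 559 nM
compound 2 `CCCCc1cncc(OC[C@@H]2CCCN2C)c1`, 0.16 nM
compound 3 `CC(C)Cc1cncc(OC[C@@H]2CCCN2C)c1`, 0.21 nM

In an assay on membranes from brain for displacement of a labelled ligand from Neuronal acetylcholine receptor; alpha4/beta2 (Rattus norvegicus) (a higher number here means a weaker inhibitor, a lower number a stronger inhibitor), compound 3 gives 0.21 nM, second highest of the three numbers; its nearest neighbour is compound 2, with a 1.3-fold higher number from compound 2 to compound 3 (0.12 log units; within the scatter), while compound 1 sits far higher. Compound 4 `CN1CCC[C@H]1COc1cncc(C(=O)N2CCCC2)c1` differs from compound 3 by (pyrrolidin-1-yl)carbonyl in place of isobutyl on an aromatic carbon. Going by the values given here, the only step measured on this ring, a 1.3-fold higher number from compound 2 to compound 3 (0.12 log units; within the scatter), swaps one saturated chain for another and stays within the scatter; no measured step trades a chain for a carbonyl-bearing group, so the change is uncharted. Compound 4 is therefore expected to be weaker, with the step of a 24-fold higher number from compound 3 to compound 4 (1.38 log units; beyond the scatter) estimated beyond the scatter. The estimate for compound 4 is 5 nM, within 0.5 nM to 50 nM.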

Compound 4, inhibition constant: 19.9 nM
Compound 4: middle estimate off by 4.0-fold (0.60 log units), on the low side, and the stated range covers the measured number.
By their numbers in this assay, from the lowest: compounds 2 and 3 (each within the scatter of the next); then compound 4; then compound 1.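

In this assay, the place two atoms from the ring nitrogen turns out to be far from indifferent to what sits there. Putting (pyrrolidin-1-yl)carbonyl on it costs much more (a 95-fold higher number from compound 3 to compound 4 (1.98 log units; beyond the scatter); a 120-fold higher number from compound 2 to compound 4 (2.09 log units; beyond the scatter)) than exchanging one saturated chain for another (a 1.3-fold higher number from compound 2 to compound 3 (0.12 log units; within the scatter)). No measurement at hand accounts for this loss.

The compounds shown leave open whether the loss goes with the carbonyl or with the pyrrolidine ring. A pyrrolidin-1-ylmethyl group, which lacks the carbonyl, or an open-chain diethylamide, which lacks the ring, would separate the two.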